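The compounds below may be only part of what the source reports. "The series", "measured", "known", "first", "only" and "open" are said of these compounds alone.

Compound 2 `CN(C)c1ccc(/C=N/Nc2nc3ccccc3nc2Cc2ccccc2)cc1` has the highest number of the two measured in an assay on isolated protein for inhibition of Amine oxidase [flavin-containing] B (Homo sapiens), read by spectrophotometry; a higher number here means a weaker inhibitor, a lower number a stronger inhibitor: compound 2 gives 880000 nM, while compound 1 `Clc1ccc(/C=N/Nc2nc3ccccc3nc2Cc2ccccc2)cc1` gives 84000 nM. Among the compounds with values here, the one measured step joins these two, a 10-fold higher number from compound 1 to compound 2 (1.02 log units; beyond the scatter), and it is the only step that bears on the change to compound 3 `Cc1ccsc1/C=N/Nc1nc2ccccc2nc1Cc1ccccc1`: 3-methylthiophen-2-yl in place of 4-(dimethylamino)phenyl on a carbon with a double bond to nitrogen. Within the data shown here, the group that leaves is the very dimethylamino-bearing ring that, in the step from compound 1 to compound 2, went with the large weakening, so removing it is expected to return a good part of that loss, though no measured compound carries a 3-methylthiophen-2-yl group and the size of the remaining gap to compound 1 is open. The step from compound 2 to compound 3 in this assay is therefore estimated as a 5.9-fold lower number from compound 2 to compound 3 (0.77 log units; beyond the scatter). Compound 3 is expected to give 150000 nM, with a range from 40000 nM to 600000 nM.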

Compound 3, half-maximal inhibitory concentration: 860000 nM
The estimate for compound 3 lay 5.7-fold (0.76 log units) below the measured number; the whole stated range lies below it.
By their numbers in this assay, from the lowest: compound 1; then compounds 3 and 2 (each within the scatter of the next).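

In this assay, placing 3-methylthiophen-2-yl instead of 4-(dimethylamino)phenyl on the carbon with a double bond to nitrogen gives no separation between the two groups (a 1.0-fold lower number from compound 2 to compound 3 (0.01 log units; within the scatter)), so the weak reading of compound 2 is not specific to the dimethylamino-bearing ring. The 3-methylthiophen-2-yl group also stands far from the 4-chlorophenyl group (a 10-fold higher number from compound 1 to compound 3 (1.01 log units; beyond the scatter)), which leaves compound 1 as the strongest inhibitor of the three and the only one set apart at this position. Nothing available explains this result.

From the compounds shown here alone, it remains open whether the chloro group itself sets compound 1 apart, or whether a bromo, methoxy or hydrogen on the same phenyl ring would read alike. Also open, going by these compounds, is how a thiophene ring without the methyl group would compare.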